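This account rests on a few compounds, and the source may have more. Where it says the series, first, only, none or still open, it means among the compounds named here.

Measured so far in an ADME assay on L929 cells (Mus musculus) for cytotoxicity, read by resazurin assay, with a stated time of 48 h; on this read-out lower numbers stand for higher toxicity in this test and higher numbers for lower toxicity in this test:
Compound 1 `N#CCn1c2ccc([N+](=O)[O-])cc2c(=O)n1Cc1ccccc1` gives > 256000 nM, which is a limit of the assay.
Compound 2 `COC(=O)CCn1c2ccc([N+](=O)[O-])cc2c(=O)n1Cc1ccccc1` gives > 256000 nM, which is a limit of the assay.
Compound 3 `O=C(O)CCCn1c2ccc([N+](=O)[O-])cc2c(=O)n1Cc1ccccc1` gives > 256000 nM, which is a limit of the assay.

Compound 3 therefore stands only at a limit in this assay, and the two further values shown are limits as well; no number separates the three. The steps a step that the two limits leave unreadable from compound 1 to compound 3 and a step that the two limits leave unreadable from compound 2 to compound 3 are both unreadable between limits, and so is a step that the two limits leave unreadable from compound 1 to compound 2. Among the measured compounds shown here, the only evidence available is the limit of > 256000 nM in this assay, at which 3 of the 3 values shown sit.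

Compound 4 `CCOC(=O)n1c2ccc([N+](=O)[O-])cc2c(=O)n1Cc1ccccc1` is the next member of the series. ethoxycarbonyl in place of 3-carboxypropyl on an aromatic nitrogen The ethoxycarbonyl enters directly on an aromatic nitrogen of a five-membered aromatic ring with 2 nitrogen, part of a fused or bridged system of two rings, where compound 3 carries the 3-carboxypropyl. For the measured compounds named here, none of the measured steps has a readable size, so no direction beyond the scatter can be drawn from them, and the three limits shared by compound 1, compound 2 and compound 3 are the whole of the record. Compound 4 is expected to sit at the limit of this assay as well, with the step that the limit leaves unreadable from compound 3 to compound 4 expected to be nil within the scatter. The estimate for compound 4 is 300000 nM, ranging from 120000 nM to 900000 nM.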

Compound 4, concentration lethal to 50% of the cells: 122000 nM
The estimate for compound 4 lay 2.5-fold (0.39 log units) above the measured number, and the stated range covers the measured number.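

In this assay, among the compounds shown here, compound 4 is the first compound to give a number rather than a limit, with ethoxycarbonyl on the aromatic nitrogen: the result is an at least 2.0-fold lower number from compound 3 to compound 4 (0.32 log units; beyond the scatter), an at least 2.0-fold lower number from compound 2 to compound 4 (0.32 log units; beyond the scatter) and an at least 2.0-fold lower number from compound 1 to compound 4 (0.32 log units; beyond the scatter). The group on this aromatic nitrogen can therefore change the read-out beyond the scatter, which cyanomethyl, 2-(methoxycarbonyl)ethyl and 3-carboxypropyl alone could not show, and the change runs towards higher toxicity in this test. All three steps start from a limit, so they give only a minimum size, and the steps among compound 1, compound 2 and compound 3 still cannot be read, leaving this as the record for those three compounds: the limit of > 256000 nM in this assay, at which 3 of the 4 values shown sit.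

The compounds shown leave open whether the lower number follows from a carbonyl set directly on the aromatic nitrogen or from the ethoxycarbonyl group as a whole. An acetyl group or a dimethylcarbamoyl group on this nitrogen would bear on that question, as would a plain propyl chain, which has no carbonyl.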